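The source may hold more compounds than are shown below. What is called first, only, known or untested is meant among the compounds shown, and "the series" means these compounds.

Measured in a functional assay on MT4 cells (Homo sapiens) for cytotoxicity; on this read-out higher numbers stand for lower toxicity in this test and lower numbers for higher toxicity in this test:
- compound 1 `COc1ccc(C(=O)CSc2nc(O)c(C)c(Cc3cccc4ccccc34)n2)cc1`: > 290000 nM (a limit)
- compound 2 `CCc1c(O)nc(SCC(=O)c2ccc(C)cc2)nc1Cc1cccc2ccccc12`: 6000 nM

For the measured compounds named here, compound 2, at 6000 nM, holds the only actual number so far. The entry for compound 1, > 290000 nM, is a limit of the assay.

Compound 3 `CCc1c(O)nc(SCC(=O)c2ccc(OC)cc2)nc1Cc1cccc2ccccc12` follows from compound 2 by one change, methoxy in place of methyl on an aromatic carbon, para to a large group: methoxy in place of methyl on an aromatic carbon. Going by the values given here, no measured step in this assay bears on this change, so the expectation is loose. A moderate move towards lower toxicity is expected, and the estimated step is a 2.5-fold higher number from compound 2 to compound 3 (0.40 log units; beyond the scatter). Compound 3 is estimated at 15000 nM, with an expected range of 4000 nM to 100000 nM.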

Compound 3, half-maximal cytotoxic concentration: 178000 nM
Beside the measured number, compound 3's estimate is 12-fold (1.07 log units) below it, outside the stated range (above it).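

In this assay, for the compounds shown here, the change from 4-methylphenyl to 4-methoxyphenyl alone gives a 30-fold higher number from compound 2 to compound 3 (1.47 log units; beyond the scatter), the first measured step, so this position can move the read-out strongly. The second step, methyl in place of hydrogen on a saturated chain carbon bound to an aromatic carbon, gives an at least 1.6-fold lower number from compound 1 to compound 3 (0.21 log units; that floor lies within the scatter); it rests on a limit and gives only a floor: the limit of > 290000 nM in this assay, at which 1 of the 3 values shown sits.

Open, going by these compounds, is whether an ethoxy, a hydroxy or a chlorine at this position moves the number as far as methoxy does. Also open, on these data alone, is whether the methoxy step holds with a different chain on the core.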